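The source may report more compounds than this note shows. Statements on the series, on what has been measured and on what is new or still open speak of the compounds shown alone.

Working notes on the dihydropyridine series

Compound 1 `COC(=O)C1=C(C)NC(C)=C(C(=O)OC)C1c1ccc(OCC(=O)n2ccnc2)c(OC)c1` and compound 2 `COC(=O)C1=C(C)NC(C)=C(C(=O)OC)C1c1cccc(OCC(=O)N2CCOCC2)c1` have both been measured in an assay on cells for inhibition of Voltage-gated L-type calcium channel (Rattus norvegicus), read by fluorescence and calcium flux, with stated times of 30 min and 2 min; on this read-out lower numbers stand for stronger inhibition and higher numbers for weaker inhibition. Compound 1 gives 10100 nM in this assay, and compound 2 gives 9900 nM. Within the data shown here, the two numbers lie within the scatter of each other, so compound 1 cannot be set apart from compound 2 on these data; the series so far shows only weak inhibition from either amide on the side chain.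

Compound 3 `COC(=O)C1=C(C)NC(C)=C(C(=O)OC)C1c1ccc(OCC(=O)N2CCCC2)c(OC)c1` is the next member and has not been measured in this assay. It differs from compound 1 in one place: pyrrolidin-1-yl in place of 1H-imidazol-1-yl on a carbonyl carbon. Among the measured compounds shown here, no step between two measured compounds with this same difference is available, so the size of this step can only be guessed. For the measured compounds named here, the single comparison on hand, compound 1 against compound 2, shows that changing the amide group and its position leaves the number where it was, within the scatter. From this the step of a 1.4-fold lower number from compound 1 to compound 3 (0.16 log units; within the scatter) is expected to be small, leaning at most toward a slightly lower number. Compound 3 is therefore expected to give about 7000 nM in this assay, with a likely range from 2500 nM to 20000 nM.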

Compound 3, half-maximal inhibitory concentration: 5600 nM
Beside the measured number, compound 3's estimate is 1.3-fold (0.10 log units) above it; the measured number falls inside the stated range.
By their numbers in this assay, from the lowest: compounds 3, 2 and 1 (each within the scatter of the next).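

In this assay, among these compounds, the only step read so far at this place, on a carbonyl carbon whose other neighbour is a saturated chain carbon, is a 1.8-fold lower number from compound 1 to compound 3 (0.26 log units; within the scatter), with pyrrolidin-1-yl in place of 1H-imidazol-1-yl. Compound 1 and compound 2 differ in more than one place and could not isolate this group, whereas this pair shows that exchanging one five-membered aromatic ring with 2 hetero atoms and 2 hydrogen-bond acceptors for one five-membered non-aromatic ring with 1 hetero atom and 0 hydrogen-bond acceptors, at 5 heavy atoms in both, keeps the number within the scatter. No supporting measurement bears on this step, so the data offer no account of it.

The compounds shown leave open whether a larger ring such as piperidin-1-yl, or an open-chain amine such as diethylamino, on the same carbonyl carbon would give a step beyond the scatter. They also leave open whether a carboxylic acid in place of the amide, or a longer chain in place of the methyl of ((pyrrolidin-1-yl)carbonyl)methoxy, would separate from compound 3.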